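Replacing the 4-bromophenyl group of compound 2

The source may hold more compounds than are shown below. What is called first, only, known or untested is meant among the compounds shown, and "the series" means these compounds.

In a functional assay on A549 cells (Homo sapiens) for antiproliferative activity, read by MTT assay (on this read-out lower numbers stand for stronger inhibition and higher numbers for weaker inhibition), compound 1 `CC1(C)CCc2cc(C(=O)/C=C/c3ccc(OCc4cn(-c5ccc(Cl)cc5)nn4)cc3)c(O)cc2O1` gives 75500 nM and compound 2 `CC1(C)CCc2cc(C(=O)/C=C/c3ccc(OCc4cn(-c5ccc(Br)cc5)nn4)cc3)c(O)cc2O1` gives 80000 nM, so the two stand within the scatter of each other. Compound 3 `Cc1c(-n2cc(COc3ccc(/C=C/C(=O)c4cc5c(cc4O)OC(C)(C)CC5)cc3)nn2)cccc1[N+](=O)[O-]` has the same core but carries 2-methyl-3-nitrophenyl in place of 4-bromophenyl on an aromatic nitrogen of a five-membered aromatic ring with 3 nitrogen, a change counted as 2-methyl-3-nitrophenyl in place of 4-bromophenyl on an aromatic nitrogen. For the measured compounds named here, only one measured step bears on this site: a 1.1-fold higher number from compound 1 to compound 2 (0.03 log units; within the scatter), with bromo in place of chloro on an aromatic carbon. Going by the values given here, that step stays within the scatter, but it is a far smaller exchange, and no measured compound carries 2-methyl-3-nitrophenyl. No step beyond the scatter is therefore expected, though with wide uncertainty. The expected step is a 1.1-fold lower number from compound 2 to compound 3 (0.06 log units; within the scatter). Compound 3 is estimated at 70000 nM, with an expected range from 30000 nM to 140000 nM.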

Compound 3, half-maximal inhibitory concentration: 65900 nM
The estimate for compound 3 lay 1.1-fold (0.03 log units) above the measured number; low and high end bracket the measured number.
By their numbers in this assay, from the lowest: compounds 3, 1 and 2 (each within the scatter of the next).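

In this assay, the exchange at the aromatic nitrogen gives a 1.2-fold lower number from compound 2 to compound 3 (0.08 log units; within the scatter), and measured against the chloro analogue it gives a 1.1-fold lower number from compound 1 to compound 3 (0.06 log units; within the scatter). Until now this site had been probed only by a swap of one halogen for another; these steps show that a quite different aryl group, 2-methyl-3-nitrophenyl, with more heavy atoms and with hydrogen-bond acceptors that 4-bromophenyl lacks, also leaves the number within the scatter. Nothing available accounts for this result.

The three compounds all carry a substituted phenyl ring on this nitrogen, so they do not show whether the ring itself matters. On these data alone, whether a phenyl ring bearing an amine or a carboxylic acid, or a plain alkyl chain in place of the ring, would give a step beyond the scatter stays open.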